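The compounds below may be only part of what the source reports. "The series", "measured", "known", "first", "only" and "open" are said of these compounds alone.

Measured compounds:
compound 1 `COc1cccc([C@]2(CO)NC[C@@H](O)[C@@H]2O)c1`: 1.6%
compound 2 `COc1cccc([C@@]2(CO)NC[C@H](O)[C@H]2O)c1`: 1.6%
compound 3 `COc1ccc([C@]2(CO)NC[C@@H](O)[C@@H]2O)cc1OC`: 0%

All three numbers come from an assay on isolated protein for inhibition of alpha-galactosidase (Coffea arabica), tested at 1000 uM (on this read-out higher numbers stand for more inhibition at the one concentration tested (going by the name of the read-out) and lower numbers for less inhibition), and lie close together. Compound 3 reads the lowest digit of the three, yet the step of a number 1.6 percentage points lower from compound 1 to compound 3 (within the scatter) stays within the scatter, and its gap to compound 2 is of the same small size, so no ranking among them is secure. The methoxy that enters on the aromatic carbon going from compound 1 to compound 3 brings no change that can be read.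

Compound 4 `COc1ccc([C@@]2(CO)NC[C@H](O)[C@H]2O)cc1OC` is the mirror image of compound 3: the two compounds have the same atoms and bonds and differ only in configuration as drawn: 3 of 3 stereo elements differ (all stereocentres are inverted: mirror images); a stereocentre at a saturated ring carbon is drawn R in compound 3 and S in compound 4; a stereocentre at a saturated ring carbon is drawn R in compound 3 and S in compound 4; a stereocentre at a saturated ring carbon is drawn R in compound 3 and S in compound 4

Among the measured compounds shown here, the one measured step of the same kind is no change at the digits printed from compound 1 to compound 2 (within the scatter), a pair that differs only in configuration as drawn (the fact that compounds 1 and 2 differ only in the configuration as drawn); that step showed no change within the scatter. The change from compound 3 to compound 4 is of the same kind on a core that differs only by one methoxy, so no step beyond the scatter is expected in this assay, and the inhibition of compound 4 is estimated to stay near the floor of the read-out.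

For compound 4 the expected value is 1%, with a range from 0% to 8%; the expected step is a number 1 percentage points higher from compound 3 to compound 4 (within the scatter).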

Compound 4, a percentage reported as inhibition, at one concentration (the size of the read-out at that concentration, not a potency): 0%
For compound 4 the middle estimate is 1 percentage points above the measured one; the measured number falls inside the stated range.
By their numbers in this assay, from the lowest: compounds 3, 4, 1 and 2 (each within the scatter of the next).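

In this assay, inverting all three stereocentres on the dimethoxy-substituted core gives no change at the digits printed from compound 3 to compound 4 (within the scatter), so the absence of a readable effect of configuration is no longer confined to one pair, and the basis for treating the two mirror-image pairs alike is: the fact that compounds 3 and 4 differ only in the configuration as drawn. The methoxy in place of hydrogen on an aromatic carbon can now be read in the opposite configuration as well, where it gives a number 1.6 percentage points lower from compound 2 to compound 4 (within the scatter), and the two readings of this change agree: the same change on two cores in this assay, a number 1.6 percentage points lower (within the scatter) from compound 1 to compound 3 and a number 1.6 percentage points lower (within the scatter) from compound 2 to compound 4, 0 percentage points apart, within the scatter of two such steps. All four compounds therefore sit within the scatter of each other at very low numbers, so neither the methoxy nor the configuration can be assigned any effect in this assay, and low numbers of this kind do not show that either change would stay without effect on a compound with readable inhibition.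

As far as these compounds go, whether a carboxylic acid or an amine on the aromatic ring, or a longer chain in place of the hydroxymethyl, would give inhibition clear of the scatter remains open. Also open, from the compounds shown here alone, is whether mirror-image compounds would separate once the numbers rise that far.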